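Swapping the Pendant Aryl Group on a Fused Core

A few compounds are considered here, and "the series" means these few. Any claim that something is new, unique, unknown or untested is made for them only; others in the source may bear on it.

Three compounds share one fused core and differ only in the aromatic group hanging from it. Compound 1 `Cc1nc2c3ccccc3ccc2c2nc3c(ccc4ccccc43)c(-c3ccccc3S)c12` carries a 2-sulfanylphenyl group, compound 2 `Cc1nc2c3ccccc3ccc2c2nc3c(ccc4ccccc43)c(-c3cccc4ccccc34)c12` a naphthalen-1-yl group, and compound 3 `COc1ccc(-c2c3ccc4ccccc4c3nc3c2c(C)nc2c4ccccc4ccc32)cc1` a 4-methoxyphenyl group. In a functional assay on HeLa cells (Homo sapiens) for cytotoxicity, read by MTT assay, with a stated time of 48 h (a higher number here means a weaker inhibitor, a lower number a stronger inhibitor), compound 1 gives 3190 nM, compound 2 gives 14900 nM, and compound 3 gives 45900 nM. Compound 3 therefore stands at the highest number of the three and is the weakest inhibitor among them, since both of its steps are beyond the scatter: a 3.1-fold higher number from compound 2 to compound 3 (0.49 log units; beyond the scatter) and a 14-fold higher number from compound 1 to compound 3 (1.16 log units; beyond the scatter).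

Compound 4 `Cc1nc2c3ccccc3ccc2c2nc3c(ccc4ccccc43)c(-c3ccccc3N)c12` is not yet measured. Its change from compound 3 is 2-aminophenyl in place of 4-methoxyphenyl on an aromatic carbon. Of the groups seen so far, the 2-aminophenyl most resembles the 2-sulfanylphenyl of compound 1, a single benzene ring bearing one small group with a hydrogen-bond donor. The step that bears most on it is therefore a 14-fold higher number from compound 1 to compound 3 (1.16 log units; beyond the scatter), which was large; if the amino group behaves like the sulfanyl group, running that step backward would give a large drop. Nothing here shows an amino group directly, so the expectation is tempered. Compound 4 is estimated at 7000 nM, with a range from 2500 nM to 20000 nM, which is expected to mean a 6.6-fold lower number from compound 3 to compound 4 (0.82 log units; beyond the scatter).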

Compound 4, half-maximal inhibitory concentration: 16200 nM
The estimate for compound 4 lay 2.3-fold (0.36 log units) below the measured number; low and high end bracket the measured number.
By their numbers in this assay, from the lowest: compound 1; then compounds 2 and 4 (each within the scatter of the next); then compound 3.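

The amino group recovers only part of what the sulfanyl group gives: in this assay, 2-aminophenyl in place of 4-methoxyphenyl brings a 2.8-fold lower number from compound 3 to compound 4 (0.45 log units; beyond the scatter), yet amino in place of sulfanyl on the same benzene ring still leaves a 5.1-fold higher number from compound 1 to compound 4 (0.71 log units; beyond the scatter), so these two small groups are not interchangeable at this position. The change to a single ring bearing an amino group also gives no measurable separation from the larger naphthalen-1-yl group, with a 1.1-fold higher number from compound 2 to compound 4 (0.04 log units; within the scatter), so among these compounds the size of the pendant aromatic group does not by itself set the order, and compound 1 remains the strongest inhibitor of the four. Nothing shown here explains these differences in cell-killing strength.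

The compounds shown leave open whether the gain in compound 1 belongs to the sulfanyl group itself or to where it sits on the ring, a question that a 4-sulfanylphenyl or a 2-methoxyphenyl group would help to answer. They also leave open how a 2-hydroxyphenyl group would rank against the amino and sulfanyl versions on the same shared core.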